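Compound 3 to compound 4: open chain for ring

The source may hold more compounds than are shown below. What is called first, only, known or untested is meant among the compounds shown, and "the series" means these compounds.

Measured in a functional assay on MCF7 cells (Homo sapiens) for cytotoxicity, read by MTT assay, with a stated time of 72 h; a lower number here means a stronger inhibitor, a higher number a weaker inhibitor:
- Compound 1 `Cc1cc(/C=C/c2ccc(O)cc2)[nH]n1`: 48100 nM
- Compound 2 `COc1ccc(/C=C/c2cc(C)n[nH]2)cc1`: 9700 nM
- Compound 3 `COc1ccc(/C=C/c2cc(C)no2)cc1OC`: > 100000 nM (a limit, not a number)

Compound 3 has no number in this assay, only a limit: the limit of > 100000 nM in this assay, at which 1 of the 3 values shown sits.

Compound 4 `COc1ccc(/C=C/C(=O)CC(C)=O)cc1OC` differs from compound 3 by a single exchange: (2-oxopropyl)carbonyl in place of 3-methyl-1,2-oxazol-5-yl on a double-bonded chain carbon bound to a double-bonded chain carbon. In words, (2-oxopropyl)carbonyl stands in place of 3-methyl-1,2-oxazol-5-yl on a double-bonded chain carbon bound to a double-bonded chain carbon. The group that leaves holds a five-membered aromatic ring, and the group that enters has no ring.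

Within the data shown here, no measured step exchanges this group. Among the measured compounds shown here, the only measured step, a 5.0-fold lower number from compound 1 to compound 2 (0.70 log units; beyond the scatter), is modest. It places methyl in place of hydrogen on an oxygen on an aromatic ring, so it does not touch the group exchanged here and guides the expected size only loosely.

A modest step toward a lower number is expected in this assay, with a real chance that compound 4 also returns only a limit. The expected step is an at least 2.5-fold lower number from compound 3 to compound 4 (0.39 log units; beyond the scatter).

Compound 4 is estimated at 40000 nM, with an expected range of 10000 nM to 100000 nM.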

Compound 4, half-maximal inhibitory concentration: 10600 nM
The estimate for compound 4 lay 3.8-fold (0.58 log units) above the measured number, and the stated range covers the measured number.
By their numbers in this assay, from the lowest: compounds 2 and 4 (each within the scatter of the next); then compound 1. At a limit, above all of these: compound 3.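

In this assay, (2-oxopropyl)carbonyl in place of 3-methyl-1,2-oxazol-5-yl on a double-bonded chain carbon bound to a double-bonded chain carbon gives an at least 9.4-fold lower number from compound 3 to compound 4 (0.97 log units; beyond the scatter) and is beyond the scatter, so the number in this pair responds to the group at this place, and the open chain, with no ring, still returns a measurable value. Among these compounds, the only other step changes a different place, with methyl in place of hydrogen on an oxygen on an aromatic ring, so this pair is the first direct reading of the group on the chain. On these data alone, the true size of the step stays unknown, and the printed size is only a lower bound, because compound 3 holds a limit and not a number: the limit of > 100000 nM in this assay, at which 1 of the 4 values shown sits.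

As far as these compounds go, it remains open whether an amide or a carboxylic acid at this place would hold the value of compound 4 at 10600 nM or lose it, and whether a longer chain would move it in either direction. Also open, from the compounds shown here alone, is whether the same exchange would give a step of similar size on the core of compound 1.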